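The source may hold more compounds than are shown below. What is called first, only, known or untested is meant among the compounds shown, and "the series" means these compounds.

Three compounds sharing a core have been taken into a functional assay on SMMC-7721 cells (Homo sapiens) for cytotoxicity, read by MTT assay, with a stated time of 48 h (a higher number here means a weaker inhibitor, a lower number a stronger inhibitor), so far. Compound 1 (`Cc1cc(Cl)cc2c(=O)cc(-c3ccccc3Cl)oc12`) has no usable result ("not determined" (no result reported)) and cannot be placed on the scale. Compound 2 (`O=c1cc(-c2ccc([N+](=O)[O-])cc2)oc2c(Cn3ccnc3)cc(Cl)cc12`) comes in at 1200 nM and compound 3 (`CN(C)Cc1cc(Cl)cc2c(=O)cc(-c3ccccc3Cl)oc12`) at 1140 nM with these two numbers inside the usual scatter of each other. Within the data shown here, compound 3 therefore stands level with the only other measured compound, and neither can be ranked above the other.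

Compound 4 (`O=c1cc(-c2ccccc2Cl)oc2c(Cn3ccnc3)cc(Cl)cc12`) differs from compound 3 in one place (1H-imidazol-1-yl in place of dimethylamino on a saturated chain carbon bound to an aromatic carbon) with 1H-imidazol-1-yl in place of dimethylamino on a saturated chain carbon bound to an aromatic carbon. Among the measured compounds shown here, no measured pair shows this change on its own, so there is no direct step to lean on. The nearest hint is compound 2, which also carries 1H-imidazol-1-yl and gives 1200 nM as its result, a number level with that of compound 3. On that basis, no step beyond the scatter is expected in this assay for this swap. The expected change is a 1.1-fold higher number from compound 3 to compound 4 (0.06 log units; within the scatter) and would be too small to count as a real difference. For compound 4 a value of 1300 nM is estimated, with 500 nM as the expected lower end and 3500 nM as the upper end of the range.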

Compound 4, half-maximal inhibitory concentration: 1070 nM
Estimate against measurement, compound 4: 1.2-fold (0.08 log units) above, and the stated range covers the measured number.
By their numbers in this assay, from the lowest: compounds 4, 3 and 2 (each within the scatter of the next).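

In this assay, the change from dimethylamino to 1H-imidazol-1-yl on a saturated chain carbon bound to an aromatic carbon now has a direct reading in a 1.1-fold lower number from compound 3 to compound 4 (0.03 log units; within the scatter) and so no longer rests on a hint from a compound that also differs elsewhere. The result shows that this place can hold either the open-chain amine or the five-membered aromatic ring with no real difference in the number, and it adds a second direct reading, for 2-chlorophenyl in place of 4-nitrophenyl on an aromatic carbon, in a 1.1-fold lower number from compound 2 to compound 4 (0.05 log units; within the scatter) with the 1H-imidazol-1-yl group held the same. No measurement at hand explains why neither change moves the number beyond the usual scatter.

The compounds shown leave open whether a different group at the chain carbon, such as a morpholine ring, a primary amine or a carboxylic acid, would shift the number. They also leave open whether an unsubstituted phenyl or a 4-methoxyphenyl on the aromatic carbon would stay level with these compounds or move away from them.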